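The compounds below may be only part of what the source reports. "The series", "measured", "known", "first", "only" and "open" are said of these compounds alone.

Values in a functional assay on MCF7 cells (Homo sapiens) for antiproliferative activity, read by MTT assay, with a stated time of 72 h (on this read-out higher numbers stand for weaker inhibition and lower numbers for stronger inhibition), for the compounds measured so far:
- compound 1 `O=C(N/N=C/c1ccc([N+](=O)[O-])cc1)Nc1ccc(Oc2ccnc3[nH]ccc23)cc1` gives 15600 nM
- compound 2 `O=C(N/N=C/c1ccc(O)cc1)Nc1ccc(Oc2ccnc3[nH]ccc23)cc1` gives 5800 nM
- compound 3 `COc1ccc(/C=N/NC(=O)Nc2ccc(Oc3ccnc4[nH]ccc34)cc2)cc1` gives "not active" (no number reported)

Compound 3 has no number to stand on: it was reported as "not active" (no number reported) in this assay and cannot be placed by size against the other two. Compound 4 `O=C(N/N=C/c1ccc(O)cc1Br)Nc1ccc(Oc2ccnc3[nH]ccc23)cc1` carries 2-bromo-4-hydroxyphenyl in place of 4-methoxyphenyl on a carbon with a double bond to nitrogen. Within the data shown here, only one measured step bears on this change, and only in part: a 2.7-fold lower number from compound 1 to compound 2 (0.43 log units; beyond the scatter) is modest and concerns hydroxy in place of nitro. Among the measured compounds shown here, no measured step leads away from compound 3 or covers the bromine, so no size can be given for the step from compound 3. For the measured compounds named here, what is expected instead is a measurable number in this assay near that of compound 2 (5800 nM), the only measured compound with a hydroxy group, with no firm direction away from it. For compound 4 the expected value is 6000 nM (estimated range 1800 nM to 20000 nM).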

Compound 4, half-maximal inhibitory concentration: "not active" (no number reported)
No number was reported for compound 4; no gap can be computed for the estimate.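

In this assay compound 3 and compound 4 were both reported as not active, without a number, so no step can be read between them. Nothing measured here explains this result. The compounds shown leave open what the bromine and the hydroxy group each do separately.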